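Compound 4: a fluorobenzoyl group replaces the tolyl arm

A few compounds are considered here, and "the series" means these few. Any claim that something is new, unique, unknown or untested is made for them only; others in the source may bear on it.

Compound 1 `Cc1cccc(NNC(=O)c2ccccc2NS(=O)(=O)c2cnc(O)nc2O)c1` is the weakest-defined member of this small set: in a functional assay on A549 cells (Homo sapiens) for antiproliferative activity, read by MTT assay, with a stated time of 24 h (a higher number here means a weaker inhibitor, a lower number a stronger inhibitor), compound 1 gives only a limit, > 20000 nM, and no number (the limit of > 20000 nM in this assay, at which 1 of the 3 values shown sits). The two compounds with measured values share a carbonyl-bearing arm instead of an aryl one. Compound 2 `CCCCOc1ccc(C(=O)NNC(=O)c2cccc(NS(=O)(=O)c3cnc(O)nc3O)c2)cc1` gives 7760 nM in this assay, and compound 3 `O=C(NNC(=O)c1ccccc1Cl)c1cccc(NS(=O)(=O)c2cnc(O)nc2O)c1` gives 3740 nM. Among the compounds with values here, the single measured step, a 2.1-fold lower number from compound 2 to compound 3 (0.32 log units; beyond the scatter), concerns the group on that carbonyl carbon and so does not touch the change considered here.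

Compound 4 `O=C(NNC(=O)c1ccccc1NS(=O)(=O)c1cnc(O)nc1O)c1ccc(F)cc1` differs from compound 1 by (4-fluorophenyl)carbonyl in place of 3-methylphenyl on an amine nitrogen. This brings compound 4 closer in outline to compounds 2 and 3, which likewise carry an aryl group on a carbonyl carbon in that arm, and both of those return numbers rather than a limit. Within the data shown here, no measured step reports what this particular change does on the core of compound 1, so the direction can be taken only from the values of compounds 2 and 3. The expectation is therefore a move into the measurable range, with considerable uncertainty: compound 4 is estimated at 8000 nM, within 2500 nM to 25000 nM, which corresponds to an expected step of an at least 2.5-fold lower number from compound 1 to compound 4 (0.39 log units; beyond the scatter).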

Compound 4, half-maximal inhibitory concentration: > 20000 nM
Compound 4 ended at the assay's limit (the forecaster's own chance of this, stated with the estimate: 25%); at least 2.5-fold (0.39 log units) between middle value and limit.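

In this assay compound 4 gives > 20000 nM, a limit of the assay and not a number. Within the data shown here, compound 1 also stands at a limit, so no step from compound 1 to compound 4 can be read. The compounds shown leave open whether (4-fluorophenyl)carbonyl in place of 3-methylphenyl on an amine nitrogen changes the activity at all.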